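Pyrrolidine to 4-methylpiperidine on the propoxy chain

A few compounds are considered here, and "the series" means these few. Any claim that something is new, unique, unknown or untested is made for them only; others in the source may bear on it.

Of the compounds shown here, three have been measured in a functional assay on MKN-45 cells (Homo sapiens) for cytotoxicity, read by MTT assay, with a stated time of 72 h; a higher number here means a weaker inhibitor, a lower number a stronger inhibitor. Compound 1 `COc1cc2c(Oc3ccc(NC(=O)c4nn(-c5ccccc5)c(=O)c5ccccc45)cc3F)ccnc2cc1OCCCN1CCCC1` gives 530 nM. Compound 2 `COc1cc2c(Oc3ccc(NC(=O)c4nn(-c5ccc(Br)cc5)c(=O)c5ccccc45)cc3F)ccnc2cc1OCCCN1CCCC1` gives 230 nM, and compound 3 `COc1cc2c(Oc3ccc(NC(=O)c4nn(-c5ccccc5Br)c(=O)c5ccccc45)cc3F)ccnc2cc1OCCCN1CCCC1` gives 410 nM. Compound 1 thus carries the highest of the three numbers; the step of a 2.3-fold lower number from compound 1 to compound 2 (0.36 log units; beyond the scatter) lies beyond the scatter, whereas the step of a 1.3-fold lower number from compound 1 to compound 3 (0.11 log units; within the scatter) does not, and the pair of bromo isomers shows a 1.8-fold higher number from compound 2 to compound 3 (0.25 log units; within the scatter).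

Compound 4 `COc1cc2c(Oc3ccc(NC(=O)c4nn(-c5ccccc5)c(=O)c5ccccc45)cc3F)ccnc2cc1OCCCN1CCC(C)CC1` is unmeasured. It differs from compound 1 by 4-methylpiperidin-1-yl in place of pyrrolidin-1-yl on a saturated chain carbon, three bonds along the chain from an oxygen on an aromatic ring. Among the measured compounds shown here, all three measured steps concern the ring on the aromatic nitrogen at the far end of the shared core; none of them touches the saturated chain or the amine at its end, so no measured step bears directly on this change. In the absence of any such step, compound 1 is taken as the anchor and no movement beyond the scatter is expected: the estimated step is a 1.1-fold lower number from compound 1 to compound 4 (0.03 log units; within the scatter). For compound 4 the expected value in this assay is therefore 500 nM, with a range from 200 nM to 1300 nM.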

Compound 4, half-maximal inhibitory concentration: 580 nM
Estimate against measurement, compound 4: 1.2-fold (0.06 log units) below, and the stated range covers the measured number.
By their numbers in this assay, from the lowest: compounds 2, 3, 1 and 4 (each within the scatter of the next, the first and the last beyond it).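

In this assay, among the compounds shown here, the change from 3-(pyrrolidin-1-yl)propyl to 3-(4-methylpiperidin-1-yl)propyl gives a 1.1-fold higher number from compound 1 to compound 4 (0.04 log units; within the scatter), so this position, which no earlier step touched, accepts a six-membered ring carrying a methyl group in place of a five-membered ring with no movement beyond the scatter. For the compounds shown here, on this single pair, the chain end differs from the ring on the aromatic nitrogen, where a 2.3-fold lower number from compound 1 to compound 2 (0.36 log units; beyond the scatter) is the one step beyond the scatter among the compounds that differ in one place. Nothing available accounts for how little the number moves here.

On these data alone, whether a morpholine, a piperazine or a carboxylic acid at the end of the chain, or a chain longer than propyl, would leave the number equally undisturbed remains open. Also open, as far as these compounds go, is whether 4-methylpiperidin-1-yl gives the same result alongside the 4-bromophenyl group of compound 2.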